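Aryl change in a potent Substance-P receptor ligand

A few compounds are considered here, and "the series" means these few. Any claim that something is new, unique, unknown or untested is made for them only; others in the source may bear on it.

Compound 1 `CC(=O)N1CC[C@@H](C(=O)N(C)Cc2cc(C(F)(F)F)cc(C(F)(F)F)c2)[C@H](c2ccccc2)C1` and compound 2 `CC(=O)N1CC[C@H](C(=O)N(C)Cc2cc(C(F)(F)F)cc(C(F)(F)F)c2)[C@H](c2ccccc2)C1` share the same atoms and bonds and differ only in configuration as drawn. In an assay on IM-9 cells for displacement of a labelled ligand from Substance-P receptor (Homo sapiens), read by scintillation counting, with a stated time of 30 min (on this read-out higher numbers stand for weaker inhibition and lower numbers for stronger inhibition), compound 1 gives 2.6 nM, and compound 2 gives 3.2 nM; the step of a 1.2-fold higher number from compound 1 to compound 2 (0.09 log units; within the scatter) goes with the fact that compounds 1 and 2 differ only in the configuration as drawn. Compound 3 `CC(=O)N1CCC(C(=O)N2CC[C@H](C(=O)N(C)Cc3cc(C(F)(F)F)cc(C(F)(F)F)c3)[C@@H](c3cccc(C)c3)C2)CC1`, which carries a 3-methylphenyl on a saturated ring carbon of its core, gives 0.14 nM in this assay, the lowest of the three numbers, with compound 1 the nearest and compound 2 the furthest of the others.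

Compound 4 `CC(=O)N1CCC(C(=O)N2CC[C@H](C(=O)N(C)Cc3cc(C(F)(F)F)cc(C(F)(F)F)c3)[C@@H](c3ccc(F)cc3C)C2)CC1` differs from compound 3 by 4-fluoro-2-methylphenyl in place of 3-methylphenyl on a saturated ring carbon. Among the measured compounds shown here, the only measured step, that between compound 1 and compound 2, concerns configuration and not the aromatic group, so no measured step bears on this change, and the data give no direction for it. Compound 4 is therefore expected to stay close to compound 3, with an expected step of a 1.4-fold higher number from compound 3 to compound 4 (0.15 log units; within the scatter) that does not go beyond the scatter. The estimate for compound 4 in this assay is 0.2 nM, expected to lie between 0.05 nM and 0.8 nM.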

Compound 4, half-maximal inhibitory concentration: 0.047 nM
Compound 4: the middle estimate sits 4.3-fold (0.63 log units) above what was measured; the measured number lies below the stated range.
By their numbers in this assay, from the lowest: compound 4; then compound 3; then compounds 1 and 2 (each within the scatter of the next).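

In this assay, 4-fluoro-2-methylphenyl in place of 3-methylphenyl on this saturated ring carbon gives a 3.0-fold lower number from compound 3 to compound 4 (0.47 log units; beyond the scatter), a modest step, but one that lies beyond the scatter. Among the compounds shown here, the earlier compounds offered only a change of configuration, a 1.2-fold higher number from compound 1 to compound 2 (0.09 log units; within the scatter), so this is the first measured sign that the aromatic group at this position can move the number, even from the already low level of compound 3. Nothing available here accounts for this step.

Compound 4 differs from compound 3 both in where the methyl sits and in the added fluorine, so the compounds shown do not separate these two changes. On these data alone, how a nitrile, a methoxy group or an amine on this aromatic ring would read also remains open.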